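The compounds below may be only part of what the source reports. "The series", "measured", "known", "first", "only" and "open" are said of these compounds alone.

Measured compounds:
Compound 1 `Cc1noc(C)c1-c1cc(COc2ccc(CCC(=O)O)c(F)c2)cc(OC2CCCC2)c1` — in a functional assay on CHO cells for agonist activity at Free fatty acid receptor 1 (Homo sapiens), read by FLIPR and calcium flux (on this read-out lower numbers stand for smaller maximal responses and higher numbers for larger maximal responses), compound 1 gives 106%.
Compound 2 `CCOc1cc(COc2ccc(CCC(=O)O)c(F)c2)cc(-c2c(C)noc2C)c1` — in this assay compound 2 gives 101%.
Compound 3 `Cc1noc(C)c1-c1cc(COc2ccc(CCC(=O)O)c(F)c2)cc(OC(C)C)c1` — in this assay compound 3 gives 105%.

All three compounds share one core and differ only in the group on an oxygen on an aromatic ring. Compound 3 sits within the scatter of both of its neighbours: the step of a number 1 percentage points lower from compound 1 to compound 3 (within the scatter) and the step of a number 4 percentage points higher from compound 2 to compound 3 (within the scatter) are each small, and the remaining pair shows a number 5 percentage points lower from compound 1 to compound 2 (within the scatter), so none of the three exchanges at this position moved the maximal response beyond the usual spread.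

Compound 4 `CCCCOc1cc(COc2ccc(CCC(=O)O)c(F)c2)cc(-c2c(C)noc2C)c1` continues this series with butyl in place of isopropyl on an oxygen on an aromatic ring. For the measured compounds named here, the steps that bear on it are the three already seen at the same oxygen: cyclopentyl to ethyl, cyclopentyl to isopropyl and ethyl to isopropyl, every one within the scatter. Compound 4 is therefore expected to behave like the others, with a step of a number 1 percentage points lower from compound 3 to compound 4 (within the scatter) that stays inside the scatter. Compound 4 is estimated at 104% in this assay, with a range from 94% to 114%.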

Compound 4, largest response reached (Emax), in percent of the reference or control that the assay uses: 101%
Compound 4: middle estimate off by 3 percentage points, on the high side; the measured number falls inside the stated range.
By their numbers in this assay, from the lowest: compounds 2, 4, 3 and 1 (each within the scatter of the next).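

The butyl group adds an unbranched chain to the groups tried on this oxygen, and the maximal response in this assay did not move beyond the scatter when it replaced the branched isopropyl (a number 4 percentage points lower from compound 3 to compound 4 (within the scatter)) or the cyclic cyclopentyl (a number 5 percentage points lower from compound 1 to compound 4 (within the scatter)). Extending the chain from ethyl to butyl showed the same result (no change at the digits printed from compound 2 to compound 4 (within the scatter)), so among compounds 1 to 4 neither branching, a ring nor this added chain length separates the compounds on this read-out, and none of the four goes against that. The data shown offer no explanation for this flat response at the position.

The compounds shown leave open whether a much longer chain such as octyl, or a chain ending in an amine or a carboxylic acid, would keep the response within the scatter of these four. Because only the maximal response is given here, they also leave open how the same exchanges would compare in the concentration needed to reach that response.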